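A few compounds are considered here, and "the series" means these few. Any claim that something is new, unique, unknown or untested is made for them only; others in the source may bear on it.

Measured compounds in a functional assay on IMR-32 cells (Homo sapiens) for antiproliferative activity, with a stated time of 72 h; on this read-out lower numbers stand for stronger inhibition and higher numbers for weaker inhibition:
- compound 1 `COc1ccc(C(=O)N(CCC(=O)NCc2ccccc2)Cc2ccc(C(=O)NO)cc2)cc1`: 1090 nM
- compound 2 `Cc1ccc(C(=O)N(CCC(=O)NCc2ccccc2)Cc2ccc(C(=O)NO)cc2)cc1`: 630 nM
- compound 3 `Cc1ccc(NC(=O)CCN(Cc2ccc(C(=O)NO)cc2)C(=O)c2ccccc2)cc1`: 550 nM

Compound 1 stands at the highest of the three numbers, but neither of the other two is separated from it by more than the scatter. Among the measured compounds shown here, the one single-point step in the set, a 1.7-fold lower number from compound 1 to compound 2 (0.24 log units; within the scatter), comes from methyl in place of methoxy on an aromatic carbon and does not exceed the scatter. For the measured compounds named here, compound 3 gives 550 nM, which likewise lies within the scatter of compound 1; no single-point step links those two.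

Compound 4 `CN(C)c1ccc(C(=O)N(CCC(=O)NCc2ccccc2)Cc2ccc(C(=O)NO)cc2)cc1` is the next compound in the series. It differs from compound 1 by dimethylamino in place of methoxy on an aromatic carbon. Going by the values given here, the only step that bears on this change is the one at the same aromatic carbon, and that step was within the scatter. Among the compounds with values here, there is no measured step for the entering group itself, so the expectation rests on that one step alone. Compound 4 is therefore expected to give a number close to that of compound 1, with a 1.2-fold lower number from compound 1 to compound 4 (0.08 log units; within the scatter) as the estimated step, and an estimate of 900 nM with a range from 400 nM to 2000 nM.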

Compound 4, half-maximal inhibitory concentration: 840 nM
Beside the measured number, compound 4's estimate is 1.1-fold (0.03 log units) above it; measured number inside the range.
By their numbers in this assay, from the lowest: compounds 3, 2, 4 and 1 (each within the scatter of the next).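

In this assay, dimethylamino in place of methoxy gives a 1.3-fold lower number from compound 1 to compound 4 (0.11 log units; within the scatter) and dimethylamino in place of methyl gives a 1.3-fold higher number from compound 2 to compound 4 (0.12 log units; within the scatter), with both steps within the scatter. Methoxy, methyl and dimethylamino at this aromatic carbon, para to a large group, therefore all give numbers within the scatter of one another, and the step from methoxy to dimethylamino, with 3 heavy atoms entering and 2 leaving, does not separate compound 4 from compound 1. No measured evidence bears on why these numbers stay so close.

On these data alone, whether a carboxylic acid, a primary amine or a longer alkoxy chain at this carbon would give a step beyond the scatter remains open. Among the compounds shown here, compound 3 is linked to compound 4 by no single-place step, so the contribution of its other amide arrangement also remains unresolved.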